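This account rests on a few compounds, and the source may have more. Where it says the series, first, only, none or still open, it means among the compounds named here.

Measured so far in a functional assay on the whole organism (strain Kunming) with Mus musculus as the target, with a stated time of 0.5 h, at a dose of 300 mg/kg by the intraperitoneal route; a higher number here means a weaker effect of the compound at the dose given, a lower number a stronger effect: compound 1 `COc1cc(OC)c(OC)cc1/C=C/COC(=O)/C=C/c1c(OC)ccc(OC)c1OC` gives 100%; compound 2 `COc1cc(OC)c(OC)cc1/C=C/COC(=O)/C=C/c1ccc(F)cc1` gives 100%; compound 3 `COc1cc(OC)c(OC)cc1/C=C/COC(=O)/C=C/c1cccc(Br)c1` gives 100%.

Compound 3 thus sits level with compound 1 and compound 2, all three reading the same at the digits reported, with the nearest and the furthest of them within the scatter. Compound 4 `COc1cc(OC)c(OC)cc1/C=C/COC(=O)/C=C/c1ccccc1Cl` differs from compound 3 in one place: 2-chlorophenyl in place of 3-bromophenyl on a double-bonded chain carbon bound to a double-bonded chain carbon. Among the measured compounds shown here, the only measured step that bears on swapping the ring at this place is no change at the digits printed from compound 2 to compound 3 (within the scatter), which left the read-out unchanged within the scatter. For the measured compounds named here, no other step is available. The step from compound 3 to compound 4 is therefore expected to show no change beyond the scatter, no change at the digits printed from compound 3 to compound 4 (within the scatter). Compound 4 is accordingly estimated at 100%, in a range from 85% to 100%.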

Compound 4, a percentage reported as activity, at one dose (the size of the read-out at that dose, not a potency): 100%
Estimate against measurement, compound 4: no gap at the digits printed; measured number inside the range.
By their numbers in this assay, from the lowest: compounds 1, 2, 3 and 4 (each within the scatter of the next).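

Under this assay the change to 2-chlorophenyl shows no change at the digits printed from compound 3 to compound 4 (within the scatter) and also no change at the digits printed from compound 2 to compound 4 (within the scatter) when set against 4-fluorophenyl. A chlorine-bearing ring therefore joins the fluorine- and bromine-bearing rings at this place, on a double-bonded chain carbon bound to a double-bonded chain carbon, and all three read alike. No measurement on hand offers an explanation for this sameness. Still open, as far as these compounds go, is whether a ring carrying an amine or a carboxylic acid, or a longer chain in place of the ring, would move the read-out at all.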